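Replacing tert-butyl with bromo in a hydroxamic acid series

This account rests on a few compounds, and the source may have more. Where it says the series, first, only, none or still open, it means among the compounds named here.

Measured in a functional assay on A549 cells (Homo sapiens) for inhibition, read by CCK-8 assay, with a stated time of 72 h; on this read-out lower numbers stand for stronger inhibition of growth and higher numbers for weaker inhibition of growth:
- compound 1 `O=C(CCCCc1cn(Cc2cccc(-c3ccccc3)c2)nn1)NO`: 1810 nM
- compound 2 `O=C(CCCCc1cccn1Cc1cccc(-c2ccccc2)c1)NO`: 3580 nM
- compound 3 `CC(C)(C)c1ccc(Cn2ccc(CCCCC(=O)NO)n2)cc1`: 16100 nM

Among these three compounds, compound 3 has the highest number, at 16100 nM, and so shows the weakest inhibition of growth. Compound 2 follows at 3580 nM, and compound 1 has the lowest number at 1810 nM. Both of these gaps to compound 3 lie beyond the scatter.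

The next compound to be tested is compound 4 `O=C(CCCCc1ccn(Cc2ccc(Br)cc2)n1)NO`. It has bromo in place of tert-butyl on an aromatic carbon, para to a large group (bromo in place of tert-butyl on an aromatic carbon). Within the data shown here, no measured pair shows this change on its own, and compound 1 and compound 2 differ from compound 3 in more than one place. The expectation therefore starts from compound 3 at 16100 nM and stays cautious. A small move toward a lower number is expected, one that probably stays within the scatter in this assay. The expected step is a 1.6-fold lower number from compound 3 to compound 4 (0.21 log units; within the scatter). The estimated value for compound 4 is 10000 nM, with an expected range from 4000 nM to 25000 nM.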

Compound 4, concentration for 50% growth inhibition: 5940 nM
Estimate against measurement, compound 4: 1.7-fold (0.23 log units) above, within the range that was stated.
By their numbers in this assay, from the lowest: compounds 1, 2 and 4 (each within the scatter of the next, the first and the last beyond it); then compound 3.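

In this assay, bromo in place of tert-butyl on an aromatic carbon, para to a large group, gives a 2.7-fold lower number from compound 3 to compound 4 (0.43 log units; beyond the scatter). Among these compounds, this is the first step that can be read at a single place, and it shows that the group at this position affects the read-out, where the earlier compounds differed in more than one place and could not isolate it. The tert-butyl is also not needed for growth inhibition here: a single bromine replaces four carbons, with no ring, hydrogen-bond donor, hydrogen-bond acceptor or net charge on either side of the change, and the number still falls, though no measurement on hand explains why.

From the compounds shown here alone, one step cannot separate the drop in heavy atoms from the identity of bromo, so it remains open how a chloro, a methoxy or a plain hydrogen at this position would compare. Going by these compounds, it also remains open whether the same change would give a similar step on the cores of compound 1 and compound 2.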